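Furan-2-yl for Propyl: Expected Cytotoxicity of Compound 4

This account rests on a few compounds, and the source may have more. Where it says the series, first, only, none or still open, it means among the compounds named here.

Measured compounds:
- compound 1, `COc1cccc(-c2nc3c(-c4ccc(Cl)cc4)n[nH]c3c(=O)n2NC(=O)c2ccncc2)c1`: 46%
- compound 2, `CCCc1n[nH]c2c(=O)n(NC(=O)c3ccccc3)c(-c3cccc([N+](=O)[O-])c3)nc12`: 33.2%
- compound 3, `CCCc1n[nH]c2c(=O)n(NC(=O)c3ccccc3)c(-c3cccc(OC)c3)nc12`: 20.7%

All three were tested in a functional assay on A549 cells (Homo sapiens) for cytotoxicity, read by sulforhodamine B assay, with a stated time of 2 days, tested at 100 uM; a lower number here means less inhibition, a higher number more inhibition at the concentration tested (going by the name of the read-out). Compound 2 stands second highest of the three numbers. Its nearest neighbour is compound 3, reached by a number 12.5 percentage points lower from compound 2 to compound 3 (beyond the scatter), a change beyond the usual scatter. Within the data shown here, compound 1 gives the highest number, but it differs from compound 2 in more than one place, so no single step links them.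

Compound 4, `O=C(Nn1c(-c2cccc([N+](=O)[O-])c2)nc2c(-c3ccco3)n[nH]c2c1=O)c1ccccc1`, has not yet been measured. It differs from compound 2 in one place: furan-2-yl in place of propyl on an aromatic carbon.

Among the measured compounds shown here, only one measured step exists, and it concerns a different position (methoxy for nitro on an aromatic carbon), so it does not bear directly on the exchange of propyl for furan-2-yl. For the measured compounds named here, no measured pair shows what replacing propyl does. The three measured numbers span a modest range, which suggests changes of moderate size are typical here.

Compound 4 is therefore expected to fall near compound 2, at an estimated 38%, within 24% to 54%. This estimate corresponds to an expected a number 4.8 percentage points higher from compound 2 to compound 4 (within the scatter), a step that may not exceed the scatter.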

Compound 4, a percentage reported as inhibition, at one concentration (the size of the read-out at that concentration, not a potency): 18.7%
For compound 4 the middle estimate is 19.3 percentage points above the measured one, and the stated range ends above it.
By their numbers in this assay, from the lowest: compounds 4 and 3 (each within the scatter of the next); then compound 2; then compound 1.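

The position on the five-membered aromatic ring that carries propyl in compound 2 is not a silent one in this assay: furan-2-yl in place of propyl gives a number 14.5 percentage points lower from compound 2 to compound 4 (beyond the scatter). Among these compounds, until now the only measured step, a number 12.5 percentage points lower from compound 2 to compound 3 (beyond the scatter), lay in a different place, so this is the first sign that a change at this position can move the number by more than the scatter, and here the change lowers it. Nothing in the available data bears on the cause of this drop.

Propyl and furan-2-yl differ in several features at once, as the open chain gives way to a ring that brings extra atoms and a ring oxygen, so this single exchange cannot show which of these features matters. A longer chain such as pentyl, or a phenyl ring, at the same place would help to separate them, and a furan-2-yl paired with methoxy instead of nitro would test whether the drop holds with the other group present.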